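The source may hold more compounds than are shown below. What is called first, only, known or untested is meant among the compounds shown, and "the series" means these compounds.

Compounds measured in an assay for displacement of a labelled ligand from Sigma non-opioid intracellular receptor 1 (Cavia porcellus), read by scintillation counting, with a stated time of 180 min; on this read-out lower numbers stand for stronger inhibition and higher numbers for weaker inhibition:
- compound 1, `COC1Cc2c(cnn2-c2ccccc2)C2(CCN(Cc3ccco3)CC2)O1`: 2.2 nM
- compound 2, `CCCN1CCC2(CC1)OC(OC)Cc1c2cnn1-c1ccccc1`: 33 nM
- compound 3, `CCCCN1CCC2(CC1)OC(OC)Cc1c2cnn1-c1ccccc1`: 8 nM

Compound 3 sits second of the three numbers in this assay: it lies a 3.6-fold higher number from compound 1 to compound 3 (0.56 log units; beyond the scatter) from compound 1 and is separated from compound 2 by a 4.1-fold lower number from compound 2 to compound 3 (0.62 log units; beyond the scatter). The step from compound 1 to compound 2 is the largest in the set, a 15-fold higher number from compound 1 to compound 2 (1.18 log units; beyond the scatter).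

Compound 4, `C=C(C)CCN1CCC2(CC1)OC(OC)Cc1c2cnn1-c1ccccc1`, has not yet been measured. Its change from compound 3 is 1-methylethenyl in place of ethyl on a saturated chain carbon, two bonds along the chain from an amine nitrogen in a ring; read one bond further out, butyl becomes 3-methylbut-3-en-1-yl.

Going by the values given here, the only measured step that speaks to a change on this chain is the extension from compound 2 to compound 3, a 4.1-fold lower number from compound 2 to compound 3 (0.62 log units; beyond the scatter), a modest lowering of the number in this assay. Compound 4 adds one further carbon to the chain of compound 3 and introduces a double bond, for which no measured comparison exists. The expectation is therefore a small step, if any, in the direction of a lower number, with a range wide enough to include no change. The estimate for compound 4 in this assay is 6 nM, within 2 nM to 20 nM, which corresponds to an expected step of a 1.3-fold lower number from compound 3 to compound 4 (0.12 log units; within the scatter).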

Compound 4, inhibition constant: 1.6 nM
Estimate against measurement, compound 4: 3.8-fold (0.57 log units) above, outside the stated range (below it).
By their numbers in this assay, from the lowest: compounds 4 and 1 (each within the scatter of the next); then compound 3; then compound 2.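

Working from this assay, the butyl chain of compound 3 is not the end of the trend on this chain: 3-methylbut-3-en-1-yl in its place gives a 5.0-fold lower number from compound 3 to compound 4 (0.70 log units; beyond the scatter), a step of about the same order as the earlier one from propyl to butyl, and the whole span from the propyl chain is a 21-fold lower number from compound 2 to compound 4 (1.31 log units; beyond the scatter). The furan-2-yl group of compound 1 also proves not to be needed for a number at this level, as a chain with no ring gives a 1.4-fold lower number from compound 1 to compound 4 (0.14 log units; within the scatter), so the two substituents cannot be told apart in this assay. No measurement at hand explains why 1-methylethenyl in place of ethyl lowers the number.

The change brings in a larger group, a branch and a double bond all at once, and the compounds shown do not separate these, so a saturated 3-methylbutyl chain and a straight pentyl chain remain the obvious comparisons. Also open, going by these compounds, is how far the chain can go on, for example whether a longer chain still, or a hydroxyl group or an amine at its end, would hold the number at this level.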